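The source may report more compounds than this note shows. Statements on the series, on what has been measured and on what is new or still open speak of the compounds shown alone.

Among the measured compounds shown here, compound 2 `COc1cc2c(Oc3c(F)cc(NC(=O)NN4C(=O)CSC4c4c(F)cccc4F)cc3F)ccnc2cc1OCCCN1CCN(C)CC1` is the only compound with a number in a functional assay on A549 cells (Homo sapiens) for antiproliferative activity, read by MTT assay, with a stated time of 72 h; on this read-out higher numbers stand for weaker inhibition and lower numbers for stronger inhibition: compound 2 gives 510 nM. Compound 1 `COc1cc2c(Oc3c(F)cc(NC(=O)NN4C(=O)CSC4c4c(F)cccc4F)cc3F)ccnc2cc1OCCCN1CCc2sccc2C1` reaches only a limit of the assay, at > 20000 nM. For the measured compounds named here, the single measured step, an at least 39-fold lower number from compound 1 to compound 2 (1.59 log units; beyond the scatter), shows that the group on that saturated chain carbon can matter greatly, with the limit of > 20000 nM in this assay, at which 1 of the 2 values shown sits, marking the weaker end of the pair. Compound 3 `COc1cc2c(Oc3c(F)cc(NC(=O)NN4C(=O)CSC4c4c(F)cccc4F)cc3F)ccnc2cc1OCCCN1C[C@H]2CCCC[C@H]2C1` carries a change at the same place: a group of 9 heavy atoms (8 carbon, 1 nitrogen; one five-membered non-aromatic ring with 1 hetero atom, one six-membered non-aromatic ring of carbon only) in place of a group of 7 heavy atoms (5 carbon, 2 nitrogen; one six-membered non-aromatic ring with 2 hetero atoms), on a saturated chain carbon, three bonds along the chain from an oxygen on an aromatic ring. This runs against the direction of the measured step, bringing back a larger bicyclic amine in place of 4-methylpiperazin-1-yl, though one without an aromatic ring, so a loss is expected rather than a gain. Compound 3 is expected to give 3000 nM, with a range from 800 nM to 15000 nM. The expected step of a 5.9-fold higher number from compound 2 to compound 3 (0.77 log units; beyond the scatter) is therefore a weakening in this assay, smaller and less certain than the measured one.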

Compound 3, half-maximal inhibitory concentration: 1930 nM
Estimate against measurement, compound 3: 1.6-fold (0.19 log units) above; low and high end bracket the measured number.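

Replacing one group with another of the same heavy-atom count on this saturated chain carbon gives an at least 10-fold lower number from compound 1 to compound 3 (1.01 log units; beyond the scatter) in this assay and so the heavy-atom count alone does not set the result at this position. Leaving 4-methylpiperazin-1-yl for the bicyclic amine costs less, with a 3.8-fold higher number from compound 2 to compound 3 (0.58 log units; beyond the scatter) as a modest step, so this place accepts more than one saturated amine, although 4-methylpiperazin-1-yl keeps the lower number. Compound 1 gives > 20000 nM as a limit of the assay and not as a number, so the first of these steps has no exact size.

Going by these compounds, how a morpholine, a piperidine or a dimethylamino group would compare on this chain remains open. So does the effect of a shorter or longer chain, or of the other stereoisomers of the bicyclic amine.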